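The compounds below may be only part of what the source reports. "The series", "measured", "known", "first", "only" and "open" are said of these compounds alone.

Compounds measured in a functional assay on the whole organism for inhibition, with Rattus norvegicus as the target, read by cytopathic effect and paw edema, at a dose of 100 mg/kg by the oral route (on this read-out higher numbers stand for more inhibition at the one dose given (going by the name of the read-out) and lower numbers for less inhibition), so far:
compound 1 `COc1cccc(NC(=O)c2c(O)c3cccnc3n(-c3ccccc3)c2=O)c1`, 20.7%
compound 2 `Cc1cnccc1NC(=O)c1c(O)c2cccnc2n(-c2ccccc2)c1=O`, 8.8%

Among the measured compounds shown here, compound 2 stands lowest of the two numbers; its nearest neighbour is compound 1, and the one measured step, a number 11.9 percentage points lower from compound 1 to compound 2 (beyond the scatter), lies beyond the scatter. Compound 3 `COc1ccc(NC(=O)c2c(O)c3cccnc3n(-c3ccccc3)c2=O)cn1` is not yet measured. It differs from compound 2 in one place: 6-methoxypyridin-3-yl in place of 3-methylpyridin-4-yl on an amide-type nitrogen. For the measured compounds named here, no measured step shares this change, so the step from compound 1 to compound 2 bears on it only loosely, in that it shows the amide-type nitrogen substituent moving this assay by a modest amount. A step of about that size in either direction, or none beyond the scatter, is plausible. Compound 3 is therefore expected near 14%, with a range from 2% to 28%, meaning an expected step of a number 5.2 percentage points higher from compound 2 to compound 3 (within the scatter).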

Compound 3, a percentage reported as inhibition, in the whole organism at one dose (the size of the read-out at that dose, not a potency): -10.2%
The estimate for compound 3 lay 24.2 percentage points above the measured number, outside the stated range (below it).
By their numbers in this assay, from the lowest: compound 3; then compound 2; then compound 1.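

In this assay, 6-methoxypyridin-3-yl on the amide-type nitrogen gives a number 19 percentage points lower from compound 2 to compound 3 (beyond the scatter) and a number 30.9 percentage points lower from compound 1 to compound 3 (beyond the scatter), so this position can move the read-out further than the earlier step showed. Methoxy stands on both 3-methoxyphenyl in compound 1 and 6-methoxypyridin-3-yl in compound 3, the two ends of this short order, so its presence alone does not set the number. Nothing at hand accounts for the fall.

Open, as far as these compounds go, is whether an amine or a carboxylic acid in place of methoxy on the pyridine ring would lift the number. Also open, from the compounds shown here alone, is what the negative number of compound 3, -10.2%, means at other doses.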